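A few compounds are considered here, and "the series" means these few. Any claim that something is new, unique, unknown or untested is made for them only; others in the source may bear on it.

Among the measured compounds shown here, compound 2 `COc1ccc(Nc2sc3ccccc3c2C#N)cc1` gives 57% in a functional assay on HUVEC cells (Homo sapiens), read by fluorescence and microscopy, with a stated time of 6 h, tested at 10 uM (a higher number here means a weaker effect of the compound at the concentration tested, a lower number a stronger effect), the higher of the two numbers measured so far; compound 1 `N#Cc1c(Nc2ccc([N+](=O)[O-])cc2)sc2ccccc12` gives 8%. For the measured compounds named here, the one step between them, a number 49 percentage points higher from compound 1 to compound 2 (beyond the scatter), is large and well beyond the scatter. Compound 3 `N#Cc1c(Nc2ccc(F)cc2)sc2ccccc12` differs from compound 2 by fluoro in place of methoxy on an aromatic carbon. Going by the values given here, the same place was exchanged in the only measured step, and that step was large, so a change beyond the scatter is expected here as well, although its size is open. For compound 3 a lower number is expected, estimated at 35% within a range of 10% to 65%, a step of a number 22 percentage points lower from compound 2 to compound 3 (beyond the scatter).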

Compound 3, a percentage reported as activity, at one concentration (the size of the read-out at that concentration, not a potency): 25%
Compound 3: the middle estimate sits 10 percentage points above what was measured; the range from low to high includes it.
By their numbers in this assay, from the lowest: compound 1; then compound 3; then compound 2.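

In this assay, the exchange of methoxy for fluoro on this aromatic carbon gives a number 32 percentage points lower from compound 2 to compound 3 (beyond the scatter), so a strong effect at this place does not depend on nitro alone. Nitro still gives the lowest number of the series: fluoro in its place gives a number 17 percentage points higher from compound 1 to compound 3 (beyond the scatter), and compound 3 therefore sits between compound 1 and compound 2, with all three steps beyond the scatter. Nothing available explains this order.

The compounds shown leave open where an amine or a carboxylic acid on this carbon would fall in the order. They also leave open whether chloro would read like fluoro.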